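Selenol to thiol on a shared quinazoline-free core: an expectation

The source may report more compounds than this note shows. Statements on the series, on what has been measured and on what is new or still open speak of the compounds shown alone.

Measured compounds:
compound 1 `COc1ccc(CNc2nc([SeH])nc3ccccc23)cc1` — > 100000 nM
compound 2 `CSc1ccc(CNc2nc([SeH])nc3ccccc23)cc1` — > 100000 nM

Of the compounds shown here, two have been measured in a functional assay on CCRF-CEM cells (Homo sapiens) for cytotoxicity, read by MTT assay, with a stated time of 72 h; a higher number here means a weaker inhibitor of growth, a lower number a stronger inhibitor of growth. Compound 1 `COc1ccc(CNc2nc([SeH])nc3ccccc23)cc1` gives only a limit of the assay, > 100000 nM. Compound 2 `CSc1ccc(CNc2nc([SeH])nc3ccccc23)cc1` likewise gives only a limit, > 100000 nM. The step that the two limits leave unreadable from compound 1 to compound 2 therefore cannot be read, since both values rest on (the limit of > 100000 nM in this assay, at which 2 of the 2 values shown sit). Compound 1 thus stands at the limit, with no number of its own to place it among the others.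

The unmeasured compound 3 `COc1ccc(CNc2nc(S)nc3ccccc23)cc1` differs from compound 1 in a single place: one sulfur atom in place of one selenium atom, on an aromatic carbon. Going by the values given here, the only measured step, from compound 1 to compound 2, changes a different part of the molecule and is itself unreadable, so no measured step bears directly on the change to a sulfanyl group. With both measured values sitting on the limit, the expected outcome for compound 3 is a step that the limit leaves unreadable from compound 1 to compound 3, that is, no change that rises beyond the scatter and most probably another limit. Compound 3 is estimated at 150000 nM, within 50000 nM to 500000 nM.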

Compound 3, concentration for total growth inhibition: 41000 nM
Compound 3: the middle estimate sits 3.7-fold (0.56 log units) above what was measured; the whole stated range lies above it.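

In this assay, going by these compounds alone, the atom on the aromatic carbon between two ring nitrogen atoms proves to matter, which the earlier compounds could not show: one sulfur atom in place of one selenium atom gives an at least 2.4-fold lower number from compound 1 to compound 3 (0.38 log units; beyond the scatter), so compound 3 is a stronger inhibitor of growth than compound 1. As far as these compounds go, compound 1 gives only a limit of the assay, > 100000 nM, so this step is a lower bound on the change and its full size stays unknown. The change at this position thus moves the read-out off the limit, whereas the step at the methoxy group, the only one available before, cannot be read: the limit of > 100000 nM in this assay, at which 2 of the 3 values shown sit.

The compounds shown rest on one pair, so they leave open whether the same exchange of selenium for sulfur would lower the number when methylsulfanyl replaces methoxy on the other aromatic ring. They also leave open how an amine, a hydroxyl or a longer chain such as ethylsulfanyl would compare with the sulfanyl group at this position.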